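The compounds below may be only part of what the source reports. "The series", "measured", "known", "first", "only" and "open" are said of these compounds alone.

In a functional assay on A549 cells (Homo sapiens) for antiproliferative activity, read by sulforhodamine B assay, with a stated time of 72 h (a higher number here means a weaker inhibitor, a lower number a stronger inhibitor), compound 1 `Cc1ccc(S(=O)(=O)Nc2cc(SCC(=O)N[C@@H](CC(C)C)B(O)O)c(O)c3ccccc23)cc1` gives 8900 nM and compound 2 `Cc1ccc(S(=O)(=O)Nc2cc(SCCC(=O)N[C@@H](CC(C)C)B(O)O)c(O)c3ccccc23)cc1` gives 8190 nM, so the two stand within the scatter of each other. Compound 3 `CC(C)C[C@H](NC(=O)CCSc1cc(NS(=O)(=O)c2ccccc2)c2ccccc2c1O)B(O)O` differs from compound 2 at one place, 4-methylphenyl to phenyl: hydrogen in place of methyl on an aromatic carbon. Among the measured compounds shown here, the only measured step, a 1.1-fold lower number from compound 1 to compound 2 (0.04 log units; within the scatter), lies elsewhere in the molecule, so it says little about this change. For the measured compounds named here, no measured step tests the methyl, so no shift beyond the scatter is expected in either direction. The expected step is a 1.1-fold higher number from compound 2 to compound 3 (0.04 log units; within the scatter). Compound 3 is estimated at 9000 nM, with an expected range of 4000 nM to 20000 nM.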

Compound 3, half-maximal inhibitory concentration: 7800 nM
The estimate for compound 3 lay 1.2-fold (0.06 log units) above the measured number, within the range that was stated.
By their numbers in this assay, from the lowest: compounds 3, 2 and 1 (each within the scatter of the next).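

In this assay, hydrogen in place of methyl on the aromatic carbon para to a large group gives a 1.1-fold lower number from compound 2 to compound 3 (0.02 log units; within the scatter). Among the compounds shown here, this is the first measured test of this position, and on these numbers the 4-methylphenyl and phenyl compounds cannot be told apart. Nothing measured here offers an explanation for this result.

Only methyl and hydrogen are compared at this position. Going by these compounds, whether an amine, a carboxylic acid or a methoxy group there would give a step beyond the scatter remains open.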